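Chloro in Place of Hydroxy on an Amide Substituent

This account rests on a few compounds, and the source may have more. Where it says the series, first, only, none or still open, it means among the compounds named here.

Compound 3 `COc1ccc(-c2cnc(NC(=O)c3ccccc3O)n2C)cc1` was tested in a toxicity assay on THP-1 cells (Homo sapiens) for inhibition; on this read-out lower numbers stand for higher toxicity in this test and higher numbers for lower toxicity in this test. In this assay compound 3 gives > 100000 nM, which is a limit of the measurement rather than a number. Compound 1 `COc1ccc(-c2cnc(NC(=O)C3CCCC3)n2C)cc1` likewise reaches only a limit, giving > 100000 nM. Compound 2 `Cn1c(-c2ccccc2)cnc1NC(=O)c1ccccc1Cl` also returns a limit, giving > 50000 nM. For the measured compounds named here, the one step that can be drawn, a step that the two limits leave unreadable from compound 1 to compound 3, stays unreadable because the limit of > 100000 nM in this assay, at which 2 of the 3 values shown sit, caps both of its ends. Compound 4 `COc1ccc(-c2cnc(NC(=O)c3ccccc3Cl)n2C)cc1` differs from compound 3 by chloro in place of hydroxy on an aromatic carbon. Going by the values given here, no measured step follows such a change. Compound 2 carries a 2-chlorophenyl group on its amide and sits at the limit of > 50000 nM in this assay, at which 1 of the 3 values shown sits. Compound 4 is therefore expected to stay at or past the same limit, a step that the limit leaves unreadable from compound 3 to compound 4, with an estimate of 150000 nM between 50000 nM and 500000 nM.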

Compound 4, half-maximal cytotoxic concentration: > 50000 nM
Compound 4: only a limit was reported; the forecaster's own chance of this, stated with the estimate: 80%; the middle value does not contradict the limit.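

For the compounds shown here, compound 1, compound 2, compound 3 and compound 4 all return only limits, so no step to compound 4 can be read. The compounds shown leave open whether chloro in place of hydroxy changes anything in this assay.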